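Methyl for hydroxy on the aryl ring of compound 2

The compounds below may be only part of what the source reports. "The series", "measured", "known", "first", "only" and "open" are said of these compounds alone.

Two compounds have results so far in a functional assay on A2780 cells (Homo sapiens) for antiproliferative activity, read by MTT assay, with a stated time of 48 h; on this read-out lower numbers stand for stronger inhibition and higher numbers for weaker inhibition. Compound 1 `COc1ccc(-c2cncc3[nH]c(=O)n(Cc4cc(OC)c(OC)c(OC)c4)c23)cc1` reads > 20000 nM, and this is a limit of the assay, not a number. Among the measured compounds shown here, compound 2 `COc1ccc(-c2cc3c(cn2)[nH]c(=O)n3-c2cc(OC)c(OC)c(OC)c2)cc1O` gives 240 nM, the only true number, so it has no measured neighbour to be ranked against.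

Compound 3 `COc1ccc(-c2cc3c(cn2)[nH]c(=O)n3-c2cc(OC)c(OC)c(OC)c2)cc1C` keeps the rest of compound 2 and alters one substituent: methyl in place of hydroxy on an aromatic carbon. Methyl takes the place of hydroxy on an aromatic carbon, ortho to a methoxy group and meta to a large group, so that 3-hydroxy-4-methoxyphenyl becomes 4-methoxy-3-methylphenyl. For the measured compounds named here, no measured step covers this exchange, so the expectation rests on the structural change alone, and it is correspondingly loose. The expected step, a 2.1-fold higher number from compound 2 to compound 3 (0.32 log units; beyond the scatter), is a small one toward weaker inhibition, close to the edge of the scatter. For compound 3 the estimated value in this assay is 500 nM, with an expected range of 120 nM to 2500 nM.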

Compound 3, half-maximal inhibitory concentration: 1530 nM
For compound 3 the middle estimate is 3.1-fold (0.49 log units) below the measured one, and the stated range covers the measured number.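

In this assay the series now has its first readable step, and it concerns the 3-hydroxy-4-methoxyphenyl group: a 6.4-fold higher number from compound 2 to compound 3 (0.80 log units; beyond the scatter). The position, on an aromatic carbon ortho to a methoxy group and meta to a large group, is therefore not indifferent to this exchange, in which hydroxy with 1 hydrogen-bond donor and 1 hydrogen-bond acceptor gives way to methyl with 0 of either, although compound 3 still gives a true number, 1530 nM, and not a limit. Nothing at hand shows which feature of the exchange accounts for the size of this step.

Going by these compounds, a single pair cannot separate the loss of the hydroxy group from the arrival of the methyl group, so it remains open whether an amine or a fluorine atom at the same position would read closer to compound 2 or to compound 3. Also open, on these data alone, is whether a larger group there, such as an ethyl chain or a carboxylic acid, would move the number further in the same direction or reverse it.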